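The source may report more compounds than this note shows. Statements on the series, on what has been measured and on what is new or still open speak of the compounds shown alone.

Of the compounds shown here, three from one series have been tested in a functional assay on A549 cells (Homo sapiens) for cytotoxicity, read by MTT assay, with a stated time of 4 days (a higher number here means a weaker inhibitor, a lower number a stronger inhibitor), and a fourth is awaiting its result.

Compound 1, with the structure `Cc1c(O)ccc2c1[C@H](Cn1cc(-c3ccccn3)nn1)[C@@]13CC(=O)[C@@](C)(CC[C@@H]21)C3`, carries a pyridin-2-yl group on its triazole ring. In this assay compound 1 gives > 20000 nM, which is a limit of the assay rather than a number. Compound 2, with the structure `Cc1c(O)ccc2c1[C@H](Cn1cc(-c3ccc(C(F)(F)F)cc3)nn1)[C@@]13CC(=O)[C@@](C)(CC[C@@H]21)C3`, carries a 4-(trifluoromethyl)phenyl group in the same place. In this assay compound 2 gives > 20000 nM, again a limit and not a measured number. The change between them is pyridin-2-yl in place of 4-(trifluoromethyl)phenyl on an aromatic carbon, and the step that the two limits leave unreadable from compound 2 to compound 1 cannot be sized, because the limit of > 20000 nM in this assay, at which 3 of the 3 values shown sit, holds both values.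

Compound 3, with the structure `C=C1C[C@]23C[C@@]1(O)CC[C@H]2c1ccc(OS(=O)(=O)c2ccc(C)cc2)c(C)c1[C@@H]3Cn1cc(-c2ccc(C(F)(F)F)cc2)nn1`, has a different core from compound 2; that difference is not broken down here. In this assay compound 3 gives > 20000 nM, which is also a limit of the assay. Compound 4, with the structure `C=C1C[C@]23C[C@@]1(O)CC[C@H]2c1ccc(OS(=O)(=O)c2ccc(C)cc2)c(C)c1[C@@H]3Cn1cc(-c2ccccn2)nn1`, is made from compound 3 by the change (pyridin-2-yl in place of 4-(trifluoromethyl)phenyl on an aromatic carbon), the same change that turns compound 2 into compound 1.

Among the compounds with values here, since every value so far sits at the same limit, as the limit of > 20000 nM in this assay, at which 3 of the 3 values shown sit, shows, the step that the limit leaves unreadable from compound 3 to compound 4 is expected to be unreadable in the same way. Compound 4 is therefore estimated at 30000 nM, most likely reported only as a limit.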

Compound 4, half-maximal inhibitory concentration: > 20000 nM
Compound 4 gave a limit, no number (the forecaster's own chance of this, stated with the estimate: 90%); the middle value lies beyond the limit too.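

In this assay, the swap of 4-(trifluoromethyl)phenyl for pyridin-2-yl cannot be sized, either between compound 3 and compound 4 or between compound 2 and compound 1, because all four results are the same limit and not numbers: the limit of > 20000 nM in this assay, at which 4 of the 4 values shown sit.

The compounds shown leave open whether this swap, or the difference in core between compound 2 and compound 3, has any effect on cytotoxicity.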